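The source may report more compounds than this note shows. Statements on the series, on what has been measured and on what is new or still open speak of the compounds shown alone.

In an ADME assay on MT4 cells (Homo sapiens) for cytotoxicity, read by MTT assay (on this read-out higher numbers stand for lower toxicity in this test and lower numbers for higher toxicity in this test), compound 1 `O=C(CSc1nncnc1-c1cccc2ccccc12)Nc1ccc(Cl)cc1Cl` gives 254000 nM. Compound 2 `O=C(CSc1nncnc1-c1ccccc1Cl)Nc1cccnc1Cl` gives 167000 nM, and compound 3 `CCOC(=O)c1ccc(NC(=O)CSc2nncnc2-c2cccc3ccccc23)c(Cl)c1` gives 150000 nM. Neither of these two values stands apart from that of compound 1 by more than the usual scatter, so compound 1 sits in a tight group of numbers. Compound 4 `O=C(CSc1nncnc1-c1cccc2ccccc12)Nc1ccccc1Br` has not yet been measured. It keeps the core of compound 1 and differs only in one group: 2-bromophenyl in place of 2,4-dichlorophenyl on an amide-type nitrogen. In words, this is 2-bromophenyl in place of 2,4-dichlorophenyl on an amide-type nitrogen. One measured step changes this same part of the structure, and it is small: a 1.7-fold lower number from compound 1 to compound 3 (0.23 log units; within the scatter). This single step offers thin evidence, but it gives no reason to expect a large shift in this assay. The estimated step is a 1.4-fold lower number from compound 1 to compound 4 (0.15 log units; within the scatter), so no clear direction is expected. For compound 4, the estimated value is 180000 nM, with an expected range from 80000 nM to 320000 nM.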

Compound 4, half-maximal cytotoxic concentration: 87000 nM
The estimate for compound 4 lay 2.1-fold (0.32 log units) above the measured number, within the range that was stated.
By their numbers in this assay, from the lowest: compounds 4, 3, 2 and 1 (each within the scatter of the next, the first and the last beyond it).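

In this assay the group on the amide-type nitrogen now gives its first step beyond the usual scatter, with a 2.9-fold lower number from compound 1 to compound 4 (0.47 log units; beyond the scatter) when 2-bromophenyl replaces 2,4-dichlorophenyl, a modest move toward higher toxicity in this test. The earlier change at this part of the structure, a 1.7-fold lower number from compound 1 to compound 3 (0.23 log units; within the scatter) and within the scatter, gave no such sign, so this place can move the number measurably, although a single step shows no more than that. No measurement shown explains why the number moves. 

Going by these compounds alone, it remains open whether the shift follows the bromine itself or the loss of the chloro groups, which a phenyl ring bearing only one chloro group could help separate. Also open, as far as these compounds go, is how the number would respond to an amine or a carboxylic acid on this phenyl ring.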